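Oxazole piperazine amides: swapping the aryl on the piperazine

A few compounds are considered here, and "the series" means these few. Any claim that something is new, unique, unknown or untested is made for them only; others in the source may bear on it.

Compound 1 `Cc1nc(-c2ccccc2)c(C(=O)N2CCN(c3cccc(C)c3C)CC2)o1` — 35 nM
Compound 2 `O=C(c1oc(C2CCCCC2)nc1-c1ccccc1F)N1CCN(c2cccc(Cl)c2)CC1` — "not active" (no number reported)

Going by the values given here, in a functional assay on HL-60 cells (Homo sapiens) for inhibition, read by MTT assay, with a stated time of 72 h (on this read-out higher numbers stand for weaker inhibition and lower numbers for stronger inhibition), compound 1 gives 35 nM, the only number reported; compound 2 differs from it in several places at once and is reported as "not active" (no number reported), so nothing can be read from that pair. Compound 3 `Cc1nc(-c2ccccc2)c(C(=O)N2CCN(c3ccc(F)cc3)CC2)o1` keeps the core of compound 1 and changes only the group on the amine nitrogen in the ring: 4-fluorophenyl in place of 2,3-dimethylphenyl on an amine nitrogen in a ring. Among the compounds with values here, with no single-change step available, a modest loss of potency, near the scatter, is expected from compound 1 to compound 3 in this assay, a 2.3-fold higher number from compound 1 to compound 3 (0.36 log units; beyond the scatter). Compound 3 is estimated at 80 nM, with a range of 25 nM to 300 nM.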

Compound 3, half-maximal inhibitory concentration: > 1000 nM
Compound 3: only a limit was reported; the forecaster's own chance of this, stated with the estimate: 10%; middle value at least 12-fold (1.09 log units) away from the limit.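

In this assay, going by these compounds alone, the group on the amine nitrogen in the ring proves decisive: 4-fluorophenyl in place of 2,3-dimethylphenyl gives an at least 28-fold higher number from compound 1 to compound 3 (1.45 log units; beyond the scatter), the first step that can be read. Compound 3 carries a limit of the assay, not a number: the limit of > 1000 nM in this assay, at which 1 of the 3 values shown sits.

The compounds shown cannot separate the loss of the two methyl groups from the entry of the fluorine, since both occur in one step. As far as these compounds go, how a 2-methylphenyl, a 3-methylphenyl or a benzyl group on that nitrogen would read remains open.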